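Growing the Branch on the Chain Bound to Nitrogen

The compounds below may be only part of what the source reports. "The series", "measured", "known", "first", "only" and "open" are said of these compounds alone.

Compound 1 `CCCCn1ccc2cc(/C(C)=C/C(=O)Nc3ccccc3OCCCC(=O)O)ccc21` gives 43 nM in an assay on Prostate gland for inhibition of steroid 5-alpha-reductase (Rattus norvegicus); on this read-out higher numbers stand for weaker inhibition and lower numbers for stronger inhibition. Compound 2 `CCCC(C)n1ccc2cc(/C(C)=C/C(=O)Nc3ccccc3OCCCC(=O)O)ccc21` gives 7.8 nM in this assay, the lower of the two numbers. Among the compounds with values here, the single measured step is a 5.5-fold lower number from compound 1 to compound 2 (0.74 log units; beyond the scatter). Compound 3 `CCCC(C(C)C)n1ccc2cc(/C(C)=C/C(=O)Nc3ccccc3OCCCC(=O)O)ccc21` pushes the same idea one size further: isopropyl in place of methyl on a saturated chain carbon bound to an aromatic nitrogen and a saturated chain carbon. Within the data shown here, only that one step bears on the change, and it points downward, but a larger branch is a different move, so the evidence is thin. A small lowering in this assay is expected, a 1.3-fold lower number from compound 2 to compound 3 (0.11 log units; within the scatter), possibly none beyond the scatter. Compound 3 is therefore estimated at 6 nM, within 2 nM to 20 nM.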

Compound 3, half-maximal inhibitory concentration: 7.2 nM
Estimate against measurement, compound 3: 1.2-fold (0.08 log units) below; low and high end bracket the measured number.
By their numbers in this assay, from the lowest: compounds 3 and 2 (each within the scatter of the next); then compound 1.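

In this assay, isopropyl in place of methyl gives a 1.1-fold lower number from compound 2 to compound 3 (0.03 log units; within the scatter), so this larger branch is accepted in this place, yet compound 2 and compound 3 cannot be told apart. Against hydrogen, isopropyl gives a 6.0-fold lower number from compound 1 to compound 3 (0.78 log units; beyond the scatter), so among these three compounds, having a branch here matters, while going from methyl to isopropyl shows no difference. Nothing available explains this result.

Still open, going by these compounds, is what a tert-butyl or cyclohexyl group would give in this place. On these data alone, a longer chain in place of the isopropyl is equally open.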